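A few compounds are considered here, and "the series" means these few. Any claim that something is new, unique, unknown or untested is made for them only; others in the source may bear on it.

Measured in a functional assay on HepG2 cells (Homo sapiens) for antiproliferative activity, read by MTT assay, with a stated time of 48 h; a higher number here means a weaker inhibitor, a lower number a stronger inhibitor:
Compound 1 `COc1ccc(/C=C/c2cc(OC)cc(OC)c2/C=C/C(=O)c2cccc(Br)c2)cc1`: 13 ug/mL
Compound 2 `COc1ccc(/C=C/c2cc(OC)cc(OC)c2/C=C/C(=O)c2ccc(OC)cc2)cc1`: 4.9 ug/mL

Compound 2 holds the lower of the two numbers, which makes it the stronger inhibitor of this pair. The next compound, compound 3 `CCN(CC)c1ccc(C(=O)/C=C/c2c(/C=C/c3ccc(OC)cc3)cc(OC)cc2OC)cc1`, has not yet been measured. It differs from compound 2 in one group: diethylamino in place of methoxy on an aromatic carbon. In words, diethylamino stands in place of methoxy on an aromatic carbon, para to a large group, so 4-methoxyphenyl becomes 4-(diethylamino)phenyl.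

Within the data shown here, only one measured step bears on this change: a 2.7-fold lower number from compound 1 to compound 2 (0.42 log units; beyond the scatter). That modest step brought in the 4-methoxyphenyl group that is now being altered, but it replaced a different group, 3-bromophenyl. Among the measured compounds shown here, no measured compound carries diethylamino, so the data set no direction for the new change. The expectation is therefore for no step beyond the scatter, with a wide margin on either side. The estimated step is a 1.2-fold higher number from compound 2 to compound 3 (0.09 log units; within the scatter). In this assay, compound 3 is expected to give about 6 ug/mL, with an estimated range of 2 ug/mL to 18 ug/mL.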

Compound 3, half-maximal inhibitory concentration: 6.3 ug/mL
For compound 3 the middle estimate is 1.1-fold (0.02 log units) below the measured one, within the range that was stated.
By their numbers in this assay, from the lowest: compounds 2 and 3 (each within the scatter of the next); then compound 1.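

In this assay, putting diethylamino, which has more heavy atoms than methoxy, in place of methoxy gives a 1.3-fold higher number from compound 2 to compound 3 (0.11 log units; within the scatter); at this place, para to a large group, the larger group therefore leaves the number within the scatter of compound 2. The other comparison gives a 2.1-fold lower number from compound 1 to compound 3 (0.31 log units; beyond the scatter), a modest step that shows 4-(diethylamino)phenyl, like 4-methoxyphenyl, sits on the lower side of 3-bromophenyl, so two different groups at this place now share that result. Nothing available explains why these groups behave alike, and no measurement speaks to the cause of either step.

The change away from 3-bromophenyl alters both the group and where it sits on the ring, so the compounds shown cannot separate those two effects, and a 4-bromophenyl group would be needed to do so. As far as these compounds go, it also remains open whether the tolerance seen here extends beyond these two groups to a primary amine, a carboxylic acid or a longer chain on the same aromatic carbon.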